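A few compounds are considered here, and "the series" means these few. Any claim that something is new, unique, unknown or untested is made for them only; others in the source may bear on it.

Compound 1 `CC1(C)O[C@H]2O[C@H]([C@@H](CCO)n3cnc4c(N)ncnc43)[C@H](Oc3ccccc3[N+](=O)[O-])[C@H]2O1`: 51800 nM
Compound 2 `CCOC(=O)C[C@H]([C@H]1O[C@@H]2OC(C)(C)O[C@@H]2[C@H]1Oc1ccccc1[N+](=O)[O-])n1cnc2c(N)ncnc21`: 119000 nM

The study reads tolerance in an ADME assay on Vero cells (Chlorocebus sabaeus) for cytotoxicity, read by fluorescence and resazurin assay, with a stated time of 3 days; a lower number here means that less compound is tolerated, a higher number that more compound is tolerated. Of the compounds shown here, two have been measured so far. Compound 1 gives 51800 nM. Compound 2 gives 119000 nM. Going by the values given here, the one step between measured compounds that differ in a single place is a 2.3-fold higher number from compound 1 to compound 2 (0.36 log units; beyond the scatter). On these two numbers compound 2 stands highest, with compound 1 as its nearest neighbour.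

Compound 3 `CCOC(=O)C[C@@H]([C@H]1O[C@@H]2OC(C)(C)O[C@@H]2[C@H]1Oc1ccccc1[N+](=O)[O-])n1cnc2c(N)ncnc21` has not yet been measured. It differs from compound 2 in this way: the two compounds have the same atoms and bonds and differ only in configuration as drawn: 1 of 5 stereo elements differ; a stereocentre at a saturated chain carbon is drawn R in compound 2 and S in compound 3. Among the compounds with values here, no measured step bears on such a change: the only step available, a 2.3-fold higher number from compound 1 to compound 2 (0.36 log units; beyond the scatter), concerns the exchange of one group for another and says nothing about an inverted stereocentre. The data therefore give no ground to expect a movement in this assay in either direction beyond the scatter. The estimated step is a 1.1-fold lower number from compound 2 to compound 3 (0.03 log units; within the scatter), meaning no change beyond the scatter is expected. Compound 3 is accordingly expected to give about 110000 nM, with a deliberately wide range from 50000 nM to 240000 nM.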

Compound 3, half-maximal cytotoxic concentration: 96300 nM
The estimate for compound 3 lay 1.1-fold (0.06 log units) above the measured number, within the range that was stated.
By their numbers in this assay, from the lowest: compounds 1, 3 and 2 (each within the scatter of the next, the first and the last beyond it).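

In this assay, inverting the stereocentre at a saturated chain carbon, drawn R on one side of the pair and S on the other, gives a 1.2-fold lower number from compound 2 to compound 3 (0.09 log units; within the scatter), so this read-out does not separate the two configurations. Going by these compounds alone, the earlier step spoke only of ethoxycarbonyl in place of hydroxymethyl, whereas this one gives the first reading on configuration at this stereocentre and shows that, with the ethoxycarbonyl chain present, the number in this assay is insensitive to the inversion within the scatter. The comparison can be tied to this single stereocentre because nothing else separates the pair: the fact that compounds 2 and 3 differ only in the configuration as drawn

Whether the inversion would be equally silent on the hydroxymethyl chain of compound 1 remains open, since only one configuration of that chain appears among the compounds shown. Also open, from the compounds shown here alone, is how the number in this assay would respond at either configuration if a carboxylic acid, an amide or a longer chain took the place of the ethoxycarbonyl group.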